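Reshaping the aryl amide: dimethyl to ethyl

The source may hold more compounds than are shown below. What is called first, only, known or untested is meant among the compounds shown, and "the series" means these compounds.

Measured so far:
compound 1 `Cc1cc(C)cc(NC(=O)CN2CCC(c3cccc[n+]3[O-])CC2)c1` gives 76%
compound 2 `c1ccc(C2CCN(Cc3nc4ccccc4[nH]3)CC2)nc1` gives 62%
compound 3 `CCOc1cccc(C(=O)NCN2CCC(c3cccc[n+]3[O-])CC2)c1` gives 54%

Three compounds have a recorded value in a functional assay on HEK293 cells for agonist activity at D(4) dopamine receptor (Homo sapiens), read by FLIPR; a lower number here means a smaller maximal response, a higher number a larger maximal response. Compound 1 stands highest of the three. Its nearest neighbour is compound 2, whose number lies lower, beyond the usual scatter; compound 3 lies furthest from it, lower still, likewise beyond the scatter. No pair among these three differs in only one place, so no single structural step can be read from the measured set.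

Compound 4 `CCc1cccc(NC(=O)CN2CCC(c3cccc[n+]3[O-])CC2)c1` has not yet been measured in this assay. It is built from the same atoms as compound 1, joined differently: 3-ethylphenyl in place of 3,5-dimethylphenyl on an amide-type nitrogen. The two aryl groups have the same count of heavy atoms, the same single six-membered aromatic ring of carbon only, no donors, no acceptors and no charge.

Among the measured compounds shown here, with no measured step of this kind to draw on, the expected step of a number 6 percentage points lower from compound 1 to compound 4 (within the scatter) is small, tending slightly downward, and may well fall within the scatter. Compound 4 is therefore estimated at 70%, with a range from 55% to 85%.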

Compound 4, largest response reached (reported as efficacy), in percent of the reference or control that the assay uses: 62%
The estimate for compound 4 lay 8 percentage points above the measured number, and the stated range covers the measured number.
By their numbers in this assay, from the lowest: compounds 3, 2 and 4 (each within the scatter of the next); then compound 1.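

In this assay, among the compounds shown here, putting 3-ethylphenyl in place of 3,5-dimethylphenyl on an amide-type nitrogen gives a number 14 percentage points lower from compound 1 to compound 4 (beyond the scatter), the first step in this set that can be read at a single place. The group that leaves and the group that enters match in every count available, with the same heavy atoms, the same six-membered aromatic ring of carbon only, no hydrogen-bond donors or acceptors and no net charge, so for this pair the maximal response is not set by those counts alone but differs with how the same carbons are joined. Nothing available explains why this rearrangement gives a lower number.

The compounds shown leave open whether the step follows from losing one of the two methyl groups or from having an ethyl group, a question that a phenyl group carrying a single methyl would help to separate. They also leave open how this position responds to other groups, such as methoxy, chlorine or a longer chain like propyl, and whether the same step would appear with a different link to the shared core.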